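Replacing Fluoro with Methoxy on the Aromatic Ring

The compounds below may be only part of what the source reports. "The series", "measured", "known", "first", "only" and "open" are said of these compounds alone.

- compound 1 `CCOC(=O)/C(=C/c1ccccc1)CN1C(=O)[C@@H](OC)[C@H]1c1ccc(Cl)cc1`: 11100 nM
- compound 2 `COC(=O)/C(=C/c1ccccc1)CN1C(=O)[C@@H](OC)[C@H]1c1ccc(F)cc1`: 21800 nM
- compound 3 `COc1ccc(OC)c([C@@H]2[C@H](OC)C(=O)N2C/C(C#N)=C/c2ccccc2)c1`: 23400 nM

In a functional assay on MDA-MB-231 cells (Homo sapiens) for antiproliferative activity, read by MTT assay, with a stated time of 48 h (a higher number here means a weaker inhibitor, a lower number a stronger inhibitor), compound 2 gives 21800 nM, a value within the scatter of those of both compound 1 and compound 3. The next compound to be tested is compound 4 `COC(=O)/C(=C/c1ccccc1)CN1C(=O)[C@@H](OC)[C@H]1c1ccc(OC)cc1`, which has methoxy in place of fluoro on an aromatic carbon, para to a large group, and otherwise matches compound 2. The change is methoxy in place of fluoro on an aromatic carbon.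

Within the data shown here, no measured pair isolates this change, so there is no direct precedent for it. The nearest guide is compound 3, which carries methoxy groups on its aromatic ring, along with a nitrile, and gives 23400 nM, within the scatter of compound 2. On that basis, the expected 1.1-fold lower number from compound 2 to compound 4 (0.04 log units; within the scatter) stays within the scatter in this assay, with no firm direction. For compound 4 the estimated value is 20000 nM, with an expected range of 8000 nM to 50000 nM.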

Compound 4, half-maximal inhibitory concentration: 14000 nM
For compound 4 the middle estimate is 1.4-fold (0.15 log units) above the measured one; low and high end bracket the measured number.
By their numbers in this assay, from the lowest: compounds 1, 4, 2 and 3 (each within the scatter of the next, the first and the last beyond it).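

In this assay, among these compounds, the exchange of fluoro for methoxy gives a 1.6-fold lower number from compound 2 to compound 4 (0.19 log units; within the scatter) and is the first direct reading of a change at this place on the ring, since the earlier compounds differ from one another in more than one place. The step stays within the scatter, so 4-fluorophenyl and 4-methoxyphenyl cannot be told apart in this assay, and the extra heavy atom and added hydrogen-bond acceptor of methoxy bring no change beyond the scatter. No measurement at hand offers an explanation for this result.

On these data alone, whether an amine or a carboxylic acid in this place would read differently remains open. So does the question of whether a methoxy group elsewhere on this aromatic ring would match this result.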